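Oxazolidinone series: lipophilicity notes toward compound 3

The source may hold more compounds than are shown below. What is called first, only, known or untested is meant among the compounds shown, and "the series" means these compounds.

Measured so far:
compound 1 `O=C1O[C@@H](CSc2cccs2)CN1c1ccc(-n2cc(-c3ccccn3)cn2)c(F)c1` 4.29
compound 2 `O=C1O[C@@H](CNC(=O)C(F)(F)F)CN1c1ccc(-n2cc(-c3ccccn3)cn2)c(F)c1` >= 1.78

In a physicochemical assay for lipophilicity, read by HPLC, measured as octanol-water partition (on this read-out higher numbers stand for higher lipophilicity and lower numbers for lower lipophilicity), compound 1 gives 4.29. Compound 2 is known in this assay only as a limit, >= 1.78. Going by the values given here, the single measured step, a step that the limit leaves unreadable from compound 1 to compound 2, is therefore of unreadable size, because the limit of >= 1.78 in this assay, at which 1 of the 2 values shown sits, sets the reading.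

Compound 3, `CONC(=O)[C@H]1CN(c2ccc(-n3cc(-c4ccccn4)cn3)c(F)c2)C(=O)O1`, differs from compound 2 by methoxycarbamoyl in place of (((trifluoromethyl)carbonyl)amino)methyl on a saturated ring carbon. Among the compounds with values here, no measured step resembles this exchange, and the one step in hand has no readable size, so the expectation rests on the standing of compound 2 alone and on the change itself, without a measured precedent for either direction. The step expected in this assay is a number at least 0.08 log units lower from compound 2 to compound 3 (that floor lies within the scatter), a small movement that may well fall within the scatter. For compound 3 the estimate is 1.7, with a range from 1 to 2.5, and a real chance that this assay again reports only a limit.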

Compound 3, partition coefficient: >= 1.58
Compound 3: only a limit was reported; the forecaster's own chance of this, stated with the estimate: 50%; the middle value lies beyond the limit too.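

In this assay compound 3 is reported only as a limit, >= 1.58. No new step can be read from compound 1 or compound 2 to compound 3. Still open, on these data alone, is where compound 2 and compound 3 actually lie, relative to compound 1 and to each other.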